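The source may report more compounds than this note shows. Statements on the series, on what has been measured and on what is new or still open speak of the compounds shown alone.

Measured in a functional assay on RS4-11 cells (Homo sapiens) for inhibition, read by CCK-8 assay, with a stated time of 48 h; on this read-out higher numbers stand for weaker inhibition and lower numbers for stronger inhibition:
Compound 1 `COc1ccc(Cc2nnc(NC(=O)/C(C#N)=C/c3ccccc3OS(=O)(=O)c3ccc(OC)cc3)s2)cc1`: 840 nM
Compound 2 `COc1ccc(Cc2nnc(NC(=O)/C(C#N)=C/c3ccccc3OS(=O)(=O)c3ccc(Cl)cc3)s2)cc1`: 4020 nM

Of these two, compound 1 has the lower number at 840 nM, and so the stronger inhibition. Compound 3 `COc1ccc(S(=O)(=O)Oc2ccccc2/C=C(\C#N)C(=O)Nc2nnc(Cc3ccc(F)cc3)s2)cc1` departs from it at the 4-methoxybenzyl group, which becomes 4-fluorobenzyl (fluoro in place of methoxy on an aromatic carbon). Among the measured compounds shown here, only one measured step bears on this, a 4.8-fold higher number from compound 1 to compound 2 (0.68 log units; beyond the scatter), where chloro replaces methoxy on an aromatic carbon. That replacement lies on a different ring, since compound 2 keeps the 4-methoxybenzyl group, so it is only a loose guide. A smaller move towards a higher number is therefore expected in this assay, and it may stay within the scatter. The expected step is a 1.8-fold higher number from compound 1 to compound 3 (0.25 log units; within the scatter). Compound 3 is estimated at 1500 nM, with an expected range of 500 nM to 4500 nM.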

Compound 3, half-maximal inhibitory concentration: 1210 nM
For compound 3 the middle estimate is 1.2-fold (0.09 log units) above the measured one, and the stated range covers the measured number.
By their numbers in this assay, from the lowest: compounds 1 and 3 (each within the scatter of the next); then compound 2.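

In this assay, only compound 3 varies the 4-methoxybenzyl group, which compound 1 and compound 2 share, and the change to 4-fluorobenzyl gives a 1.4-fold higher number from compound 1 to compound 3 (0.16 log units; within the scatter). Among the compounds shown here, on this ring, then, fluoro in place of methoxy stays within the scatter, whereas the only other step, a 4.8-fold higher number from compound 1 to compound 2 (0.68 log units; beyond the scatter), puts chloro in place of methoxy on the other ring and lies beyond it; since both the ring and the incoming group differ, the two steps do not separate the effect of either. No measurement is available that explains this result.

The compounds shown leave open whether this ring tolerates other replacements for methoxy, such as an amine, a carboxylic acid or a longer chain like butoxy. They also leave open how fluoro behaves on the other ring, and how chloro behaves on this one.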